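The compounds below may be only part of what the source reports. "The series", "measured", "known", "first", "only" and "open" are said of these compounds alone.

In an ADME assay on microsomes from liver (Homo sapiens) for metabolic stability, with a stated time of 10 min (on this read-out higher numbers stand for a more stable compound and lower numbers for a less stable compound), compound 1 `FC(F)(F)c1ccccc1-c1ccc2[nH]c(C3=NOC4(CCCCC4)C3)nc2c1` gives 100%. Level with it, compound 2 `FC(F)(F)c1ccccc1-c1cc(Br)c2[nH]c(C3=NOC4(CCCCC4)C3)nc2c1` gives 100%, so it stands at the top of the scale alongside the only other measured compound. For the measured compounds named here, the single measured step, bromo in place of hydrogen on an aromatic carbon, shows no change at the digits printed from compound 1 to compound 2 (within the scatter). Compound 3 `OCCCc1cc(-c2ccccc2C(F)(F)F)cc2nc(C3=NOC4(CCCCC4)C3)[nH]c12` changes that same substituent: 3-hydroxypropyl in place of bromo on an aromatic carbon. Going by the values given here, the measured step offers only limited guidance here, as no measured compound carries a 3-hydroxypropyl group, and the data contain no step that adds a chain of any kind. With compound 2 at 100%, this assay leaves room for a fall but not for a rise. A modest loss is therefore the likelier outcome, although a result level with compound 2 remains possible. The expected step is a number 15 percentage points lower from compound 2 to compound 3 (beyond the scatter). Compound 3 is estimated at 85%, with an expected range of 60% to 100%.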

Compound 3, percent of the compound remaining: 57%
Estimate against measurement, compound 3: 28 percentage points above; measured number below the stated range.
By their numbers in this assay, from the lowest: compound 3; then compounds 1 and 2 (each within the scatter of the next).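

At this position, ortho to a fused ring, the two earlier compounds gave no sign that the substituent mattered, since bromo and hydrogen read the same in this assay. Putting 3-hydroxypropyl in place of bromo gives a number 43 percentage points lower from compound 2 to compound 3 (beyond the scatter), and putting it in place of hydrogen gives a number 43 percentage points lower from compound 1 to compound 3 (beyond the scatter), so the site does respond to what it carries, and the size of the change is the same from either starting point. Why this chain has such an effect remains unexplained, as nothing measured here speaks to the cause of the fall.

The compounds shown leave open whether the loss goes with the terminal hydroxyl or with the carbon chain itself, a question that a plain propyl group, a shorter hydroxyethyl chain, a longer chain, or an amine or a carboxylic acid at the chain end would help to settle. They also leave open whether 3-hydroxypropyl would produce the same fall at another carbon of the six-membered aromatic ring, or whether the effect belongs to this position alone.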